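The compounds below may be only part of what the source reports. "The series", "measured", "known", "first", "only" and "open" are said of these compounds alone.

Compound 1 `O=C(Nc1cc(Nc2ccc(Cl)cc2)ncn1)c1ccc(F)cc1` and compound 2 `COc1ccc(OC)c(Nc2cc(Nc3ccc(F)cc3)ncn2)c1` share one core and were both tested in an assay for inhibition of Receptor tyrosine-protein kinase erbB-3 variant L858R (Homo sapiens), read by mobility shift assay, with a stated time of 10 min; on this read-out higher numbers stand for weaker inhibition and lower numbers for stronger inhibition. In this assay compound 1 gives 1610 nM, while compound 2 gives 230 nM, the lower of the two numbers, a gap wide enough to count as a real difference. Compound 3 `COc1ccc(OC)c(Nc2cc(NC(=O)CCCC(=O)O)ncn2)c1` has not been measured yet. It differs from compound 2 in one place: (3-carboxypropyl)carbonyl in place of 4-fluorophenyl on a nitrogen on an aromatic ring. In words, a (3-carboxypropyl)carbonyl takes the place of a 4-fluorophenyl on a nitrogen attached to the core, so an aromatic ring gives way to a short open chain ending in a carboxylic acid. Without any measured pair of this kind to lean on, the expectation is a clear loss, a step of about a 22-fold higher number from compound 2 to compound 3 (1.34 log units; beyond the scatter) toward weaker inhibition. Compound 3 is therefore estimated at around 5000 nM, with a plausible range from 1000 nM to 30000 nM.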

Compound 3, half-maximal inhibitory concentration: > 10000 nM
Compound 3 was reported as a limit; the forecaster's own chance of this, stated with the estimate: 25%; at least 2.0-fold (0.30 log units) between middle value and limit.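

Replacing the 4-fluorophenyl on this nitrogen with a (3-carboxypropyl)carbonyl gives an at least 43-fold higher number from compound 2 to compound 3 (1.63 log units; beyond the scatter), which shows that the group at this place strongly affects the reading in this assay. Among the compounds shown here, this is the first single-place change, and it is a large step toward weaker inhibition. For compound 3, the reading of > 10000 nM is a limit of the assay and not a number, so only the smallest possible size of the step is known: the limit of > 10000 nM in this assay, at which 1 of the 3 values shown sits.

The change removes an aromatic ring and brings in a carbonyl, an open chain and a carboxylic acid all at once, so the compounds shown cannot say which of these parts matters. A plain butanoyl chain or a benzoyl group on the same nitrogen would help separate those parts.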